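The source may hold more compounds than are shown below. What is called first, only, known or untested is meant among the compounds shown, and "the series" means these compounds.

Cytotoxicity in the series is read in an ADME assay on MT4 cells (Homo sapiens) for cytotoxicity, read by MTT assay, with a stated time of 5 days; a lower number here means that less compound is tolerated, a higher number that more compound is tolerated. Compound 1 `COc1ccc(C(=O)c2ccccc2)c(Oc2ccnc(Nc3ccc(C#N)cc3)n2)c1` gives 760 nM there. Compound 2 `N#Cc1ccc(Nc2nccc(Oc3ccc(C(=O)c4ccc(O)cc4)cc3)n2)cc1` gives 19400 nM in this assay. Compound 3 `N#Cc1ccc(Nc2nccc(Oc3ccc(OCc4ccccc4)cc3)n2)cc1` sits at the limit of > 316000 nM in this assay, at which 1 of the 3 values shown sits, so for compound 3 the value > 316000 nM is a limit of this assay and not a number. Among the measured compounds shown here, the only measured step that bears on the next change is an at least 16-fold higher number from compound 2 to compound 3 (1.21 log units; beyond the scatter), a large upward move from a measured number to the limit. Compound 4 `COCCc1ccc(Oc2ccnc(Nc3ccc(C#N)cc3)n2)cc1` differs from compound 3 by 2-methoxyethyl in place of benzyloxy on an aromatic carbon. For the measured compounds named here, no measured step covers this exchange itself; the one step measured at the same position of the shared core was large and in the direction of more tolerated compound. Compound 4 is therefore expected to remain well tolerated, with the step of an at least 2.1-fold lower number from compound 3 to compound 4 (0.32 log units; beyond the scatter) expected to be none beyond the scatter or a modest drop back into the measurable range. The estimate for compound 4 in this assay is 150000 nM, expected to lie between 40000 nM and 316000 nM.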

Compound 4, half-maximal cytotoxic concentration: 93300 nM
For compound 4 the middle estimate is 1.6-fold (0.21 log units) above the measured one; low and high end bracket the measured number.
By their numbers in this assay, from the lowest: compound 1; then compound 2; then compound 4. At a limit, above all of these: compound 3.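

At this position, para to a large group, this assay now has a measured number for a group without a ring: 2-methoxyethyl in place of benzyloxy gives an at least 3.3-fold lower number from compound 3 to compound 4 (0.52 log units; beyond the scatter), and that size is only a lower bound. Compound 3 stays at a limit of the assay and not at a number: the limit of > 316000 nM in this assay, at which 1 of the 4 values shown sits. 2-Methoxyethyl in place of (4-hydroxyphenyl)carbonyl gives a 4.8-fold higher number from compound 2 to compound 4 (0.68 log units; beyond the scatter), so the group without a ring holds the higher number of that pair.

The compounds shown leave open whether a longer chain, a terminal amine or a carboxylic acid at this position would stay in the measurable range. On these data alone, how far compound 4 truly lies from compound 3 also stays open, and compound 1 differs from the others in more than one place.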